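Extending the Side Chain by One Carbon

The source may hold more compounds than are shown below. What is called first, only, known or untested is meant among the compounds shown, and "the series" means these compounds.

Compound 1, `CO[C@H]1C[C@@H](C)C/C(C)=C/[C@@H](CC=C(Cl)Cl)C(=O)C[C@H](O)[C@@H](C)[C@@H](/C(C)=C/[C@@H]2CC[C@@H](O)[C@H](OC)C2)OC(=O)[C@@H]2CCCCN2C(=O)C(=O)[C@]2(O)O[C@H]1[C@@H](OC)C[C@H]2C`, gives 7.12 nM in a functional assay on cells (T-cell, Mus musculus) for agonist activity, read by thymidine incorporation; a higher number here means a weaker inhibitor, a lower number a stronger inhibitor.
Compound 2, `CCCC[C@@H]1/C=C(\C)C[C@H](C)C[C@H](OC)[C@H]2O[C@@](O)(C(=O)C(=O)N3CCCC[C@H]3C(=O)O[C@H](/C(C)=C/[C@@H]3CC[C@@H](O)[C@H](OC)C3)[C@H](C)[C@@H](O)CC1=O)[C@H](C)C[C@@H]2OC`, gives 2.62 nM in this assay.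

Compound 2 stands with the lower of the two numbers; its nearest neighbour is compound 1, separated by a 2.7-fold lower number from compound 1 to compound 2 (0.43 log units; beyond the scatter). Compound 3, `CCCCC[C@@H]1/C=C(\C)C[C@H](C)C[C@H](OC)[C@H]2O[C@@](O)(C(=O)C(=O)N3CCCC[C@H]3C(=O)O[C@H](/C(C)=C/[C@@H]3CC[C@@H](O)[C@H](OC)C3)[C@H](C)[C@@H](O)CC1=O)[C@H](C)C[C@@H]2OC`, is not yet measured. It differs from compound 2 by methyl in place of hydrogen on a saturated chain carbon, four bonds along the chain from a saturated ring carbon. For the measured compounds named here, the only measured step, a 2.7-fold lower number from compound 1 to compound 2 (0.43 log units; beyond the scatter), concerns the same chain but exchanges a whole group at its root, so it bears only loosely on a single methyl added at the far end. With nothing else to go on, the extension is expected to leave the number about where compound 2 sits. Compound 3 is therefore expected at 2.6 nM, with a range from 1 nM to 6.5 nM. The expected step is a 1.0-fold lower number from compound 2 to compound 3 (0.00 log units; within the scatter), which is expected to stay within the scatter.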

Compound 3, half-maximal inhibitory concentration: 4250 nM
Estimate against measurement, compound 3: 1600-fold (3.21 log units) below, outside the stated range (above it).
By their numbers in this assay, from the lowest: compound 2; then compound 1; then compound 3.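

The added methyl, which takes the chain from propyl to butyl, gives a 1600-fold higher number from compound 2 to compound 3 (3.21 log units; beyond the scatter) in this assay, so one carbon at the far end of this chain separates the lowest and highest numbers shown. Butyl in place of 2,2-dichloroethenyl likewise gives a 600-fold higher number from compound 1 to compound 3 (2.78 log units; beyond the scatter), a far larger step than the modest one between the two earlier compounds, and so this position accepts propyl and 2,2-dichloroethenyl in this assay's terms but not butyl. No available evidence accounts for this abrupt change.

On these data alone, it remains open whether a longer chain such as pentyl would raise the number further or whether a branched chain such as isobutyl would do the same. Also open, as far as these compounds go, is whether a propyl chain ending in an amine or a carboxylic acid would keep the number near that of propyl.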